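Methylating the Bridging Nitrogen of a Transporter Inhibitor

A few compounds are considered here, and "the series" means these few. Any claim that something is new, unique, unknown or untested is made for them only; others in the source may bear on it.

Measured so far:
compound 1 `N#Cc1ccc(Nc2cnccc2SCc2ccccc2C(=O)O)c2ccccc12`, 240 nM
compound 2 `N#Cc1ccc(Nc2cnccc2SCCCC(=O)O)c2ccccc12`, 2780 nM
compound 3 `N#Cc1ccc(Nc2cnccc2SCCCCCCC(=O)O)c2ccccc12`, 5750 nM

All three were tested in an assay on HEK293 cells for inhibition of solute carrier family 22 member 12 (Homo sapiens), read by scintillation counting, with stated times of 30 min and 15 min; a lower number here means a stronger inhibitor, a higher number a weaker inhibitor. Compound 2 stands second highest of the three numbers: the nearest number is reached by a 2.1-fold higher number from compound 2 to compound 3 (0.32 log units; beyond the scatter), the furthest by a 12-fold higher number from compound 1 to compound 2 (1.06 log units; beyond the scatter). Compound 4 `CN(c1cnccc1SCCCC(=O)O)c1ccc(C#N)c2ccccc12` differs from compound 2 by methyl in place of hydrogen on a nitrogen on an aromatic ring. Within the data shown here, none of the measured steps touches this nitrogen; each of them, a 24-fold higher number from compound 1 to compound 3 (1.38 log units; beyond the scatter) included, changes the carboxylic acid-bearing group on the sulfur instead. Among the measured compounds shown here, with no step bearing on it, the change is expected to leave the number close to that of compound 2, within or only slightly beyond the scatter, and its direction cannot be told from these data. Compound 4 is therefore estimated at 4000 nM, with a range from 1000 nM to 16000 nM, meaning an expected 1.4-fold higher number from compound 2 to compound 4 (0.16 log units; within the scatter).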

Compound 4, half-maximal inhibitory concentration: 2580 nM
For compound 4 the middle estimate is 1.6-fold (0.19 log units) above the measured one, within the range that was stated.
By their numbers in this assay, from the lowest: compound 1; then compounds 4 and 2 (each within the scatter of the next); then compound 3.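

In this assay, among these compounds, methyl in place of hydrogen on a nitrogen on an aromatic ring gives a 1.1-fold lower number from compound 2 to compound 4 (0.03 log units; within the scatter), so this nitrogen, untouched by the earlier steps, accepts a methyl without a change beyond the scatter. For this pair, the hydrogen on that nitrogen is not needed to keep the number. No measurement shown here explains this result. Going by these compounds, it remains open whether an ethyl or acetyl group on this nitrogen would be accepted as well, and whether methyl there would behave the same way alongside the 2-carboxyphenyl group of compound 1.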